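This account rests on a few compounds, and the source may have more. Where it says the series, first, only, none or still open, it means among the compounds named here.

Working notes on the series. In a functional assay on A875 cells (Homo sapiens) for antiproliferative activity, read by MTT assay, with a stated time of 48 h (on this read-out higher numbers stand for weaker inhibition and lower numbers for stronger inhibition), compound 1 `O=C(CSc1nnc(NC(=O)CCl)s1)Nc1ccc(Br)cn1` gives 13900 nM and compound 2 `O=C(CSc1nnc(NC(=O)CCCl)s1)Nc1ccc(Br)cn1` gives 430 nM. The change chloromethyl in place of chloro on a saturated chain carbon bound to a carbonyl carbon produces a 32-fold lower number from compound 1 to compound 2 (1.51 log units; beyond the scatter). Compound 3 `O=C(CCl)Nc1ccc(SCC(=O)Nc2cc(Cl)ccn2)cc1` has a different core; the difference between the two cores is not broken down here. In this assay compound 3 gives 850 nM, which places it within the scatter of compound 2 and well apart from compound 1. Compound 4 `O=C(CCCl)Nc1ccc(SCC(=O)Nc2cc(Cl)ccn2)cc1` is not yet measured and carries the same change as before, (chloromethyl in place of chloro on a saturated chain carbon bound to a carbonyl carbon), at the same place. A step in the same direction is expected for compound 4, though smaller than the earlier one, since it rests on a single pair; the expected step is an 8.5-fold lower number from compound 3 to compound 4 (0.93 log units; beyond the scatter). Compound 4 is therefore estimated at 100 nM, with a range from 30 nM to 400 nM.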

Compound 4, half-maximal inhibitory concentration: 12300 nM
Beside the measured number, compound 4's estimate is 120-fold (2.09 log units) below it, outside the stated range (above it).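

In this assay the change from chloro to chloromethyl, on a saturated chain carbon bound to a carbonyl carbon, gives a 14-fold higher number from compound 3 to compound 4 (1.16 log units; beyond the scatter), the reverse of its direction on the core of compound 1. The effect of this change therefore differs between the two cores, in direction as well as in size: the same change on two cores in this assay, a 32-fold lower number (1.51 log units; beyond the scatter) from compound 1 to compound 2 and a 14-fold higher number (1.16 log units; beyond the scatter) from compound 3 to compound 4, 470-fold (2.67 log units) apart, beyond the scatter of two such steps. The step seen on one core thus cannot be carried to the other in this series, but with one pair per core this does not show which part of the cores is responsible, nor what the change would do on a further core.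

Still open, from the compounds shown here alone, is how a longer chain carrying the chlorine would behave on each core. Also open, going by these compounds, is whether an amine in place of the chlorine would keep the same difference between the two cores.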